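Shortening an Octyl Chain: What Cytotoxicity to Expect

The source may report more compounds than this note shows. Statements on the series, on what has been measured and on what is new or still open speak of the compounds shown alone.

Compound 1 `CCCCCCCCNc1nccnc1C(=O)NCc1ccccc1` carries an octyl chain on a ring nitrogen and a benzylamide on its aromatic core. For the measured compounds named here, in an ADME assay on MDCK cells (Canis lupus familiaris) for cytotoxicity, read by microscopy, with a stated time of 6 days (on this read-out higher numbers stand for lower toxicity in this test and lower numbers for higher toxicity in this test), compound 1 gives 100000 nM, the only full number in this small set. Compound 2 `CCCCCCCCNc1cnc(C(=O)NCc2ccccc2)cn1` is an isomer bearing the same groups on the shared core. In this assay compound 2 reaches only a limit, >= 20000 nM, which marks an edge of the test rather than a measured number (the limit of >= 20000 nM in this assay, at which 1 of the 2 values shown sits). Going by the values given here, with one number and one limit, no step between measured compounds can be drawn.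

Compound 3 `CCCCNc1nccnc1C(=O)NCc1ccccc1` is the unmeasured companion of compound 1. The change hydrogen in place of butyl on a saturated chain carbon, four bonds along the chain from a nitrogen on an aromatic ring shortens the chain on a saturated chain carbon. Because compound 1 already sits at 100000 nM, little room for a rise remains. The expected step of no change at the digits printed from compound 1 to compound 3 (within the scatter) is none beyond the usual scatter. Compound 3 is therefore expected to give about 100000 nM, within 50000 nM to 200000 nM.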

Compound 3, minimum cytotoxic concentration: > 100000 nM
Compound 3 gave a limit, no number; the forecaster's own chance of this, stated with the estimate: 40%; the middle value lies on the limit itself.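

Replacing butyl with hydrogen on a saturated chain carbon, four bonds along the chain from a nitrogen on an aromatic ring, turns the octyl chain into a butyl chain, and in this assay this gives a number no lower from compound 1 to compound 3 (the limit leaves the size open). At this position, then, removing these four carbons brings no sign of higher toxicity in this test, something compound 1 alone could not show. How far the read-out moved stays unknown, since the result for compound 3 is a limit and not a number: the limit of > 100000 nM in this assay, at which 1 of the 3 values shown sits.

Going by these compounds, whether the same shortening would act alike in compound 2, the isomer whose result is also a limit, remains open. Also open, on these data alone, is how this assay would read for a hexyl chain at this place, or for a chain ending in an amine or a carboxylic acid.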